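The source may report more compounds than this note shows. Statements on the series, on what has been measured and on what is new or still open speak of the compounds shown alone.

Series notes. Compound 2 `Cc1[nH]c2ccccc2c1C(C1=C(O)C(=O)c2ccccc2C1=O)c1ccc([N+](=O)[O-])cc1` gives 15100 nM in a toxicity assay (Homo sapiens) for cytotoxicity, read by MTT assay, with a stated time of 48 h (a lower number here means a stronger inhibitor, a higher number a weaker inhibitor), the lowest of the three measured numbers. Compound 1 `O=C1C(O)=C(C(c2ccccc2)c2c(-c3ccccc3)[nH]c3ccccc23)C(=O)c2ccccc21` gives 26400 nM, within the scatter of compound 2, so the two are not ordered. For the measured compounds named here, compound 3 `O=C1C(O)=C(C(c2ccc([N+](=O)[O-])cc2)c2c[nH]c3ccc(Br)cc23)C(=O)c2ccccc21` gives 45200 nM; the single one-place step in the set is a 3.0-fold higher number from compound 2 to compound 3 (0.48 log units; beyond the scatter), which does not touch the change considered here. Compound 4 `O=C1C(O)=C(C(c2ccc([N+](=O)[O-])cc2)c2c(-c3ccccc3)[nH]c3ccccc23)C(=O)c2ccccc21` differs from compound 2 by phenyl in place of methyl on an aromatic carbon. Going by the values given here, no measured step covers this change alone. Compound 1 carries the same phenyl that compound 4 carries, but it differs from compound 2 in a second place as well, so the number for compound 1, 26400 nM, is only a loose pointer, and it sits within the scatter of compound 2. The step of a 1.5-fold higher number from compound 2 to compound 4 (0.16 log units; within the scatter) is therefore estimated as no change beyond the scatter. For compound 4 the estimate in this assay is 22000 nM, ranging from 9000 nM to 55000 nM.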

Compound 4, half-maximal inhibitory concentration: 14200 nM
Beside the measured number, compound 4's estimate is 1.5-fold (0.19 log units) above it, and the stated range covers the measured number.
By their numbers in this assay, from the lowest: compounds 4, 2, 1 and 3 (each within the scatter of the next, the first and the last beyond it).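

On the aromatic carbon next to the ring nitrogen, phenyl in place of methyl now has a step of its own in this assay, a 1.1-fold lower number from compound 2 to compound 4 (0.03 log units; within the scatter), so this exchange shows no change beyond the scatter while the rest of the structure stays fixed. With phenyl held at that position, nitro in place of hydrogen on an aromatic carbon gives a 1.9-fold lower number from compound 1 to compound 4 (0.27 log units; within the scatter), so this second change also stays inside the scatter. No measurement at hand offers an explanation for either step.

Going by these compounds, whether an amine or a carboxylic acid at this position would move the number beyond the scatter remains open. Also open, on these data alone, is the number for methyl at this position with hydrogen in place of nitro, which would test the two changes together.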